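The compounds below may be only part of what the source reports. "The series", "measured", "known", "first", "only" and "open" are said of these compounds alone.

Measured so far in an ADME assay on microsomes from liver (Homo sapiens) for pharmacokinetics; on this read-out lower numbers stand for slow clearance and higher numbers for fast clearance:
- compound 1 `Cc1nn(CC2(O)COC2)cc1Nc1nc(N)c2c(C#N)c(N3CCC[C@H]3C)n(C)c2n1` gives 76.7 mL/min/kg
- compound 2 `C[C@@H]1CCCN1c1c(C#N)c2c(N)nc(Nc3cn(C)nc3Cl)nc2n1C` gives 183 mL/min/kg
- compound 3 `Cc1c(Nc2nc(N)c3c(C#N)c(N4CCC[C@H]4C)n(C)c3n2)cnn1CC1(O)COC1` gives 35 mL/min/kg

Compound 1 stands second highest of the three numbers in this assay. Its nearest neighbour is compound 3, whose number is lower by a margin beyond the scatter; furthest from it is compound 2, whose number is higher, again beyond the scatter. Within the data shown here, no two measured compounds differ in only one place, so the series gives no step size of its own to lean on.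

Compound 4 `Cc1nn(CC(C)(C)O)cc1Nc1nc(N)c2c(C#N)c(N3CCC[C@H]3C)n(C)c2n1` is not yet measured. It differs from compound 1 in one place: 1-hydroxy-1-methylethyl in place of 3-hydroxyoxetan-3-yl on a saturated chain carbon bound to an aromatic nitrogen. The same difference, cut one bond further out, reads (3-hydroxyoxetan-3-yl)methyl to 2-hydroxy-2-methylpropyl; the shared core is untouched.

Among the measured compounds shown here, with no comparable step in hand, the expected step of a 1.2-fold higher number from compound 1 to compound 4 (0.09 log units; within the scatter) is a modest rise in clearance, of a size at or only just beyond the usual scatter, and the direction is held loosely. Compound 4 is therefore estimated at 95 mL/min/kg, with a range from 45 mL/min/kg to 190 mL/min/kg, wide enough to cover no change at all from compound 1 as well as a step up toward the number of compound 2.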

Compound 4, clearance: 50 mL/min/kg
The estimate for compound 4 lay 1.9-fold (0.28 log units) above the measured number; measured number inside the range.
By their numbers in this assay, from the lowest: compounds 3, 4 and 1 (each within the scatter of the next, the first and the last beyond it); then compound 2.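

In this assay, this place now has its first readable step: 1-hydroxy-1-methylethyl in place of 3-hydroxyoxetan-3-yl on a saturated chain carbon bound to an aromatic nitrogen gives a 1.5-fold lower number from compound 1 to compound 4 (0.19 log units; within the scatter). The four-membered non-aromatic ring can therefore leave this side chain without a difference in clearance that can be told from the scatter, and the hydroxyl-bearing carbon stays in both groups, so the oxetane ring and the open 2-hydroxy-2-methylpropyl chain read alike here. Nothing measured on either group bears on this result.

The compounds shown leave open how much change this place allows: whether an amine, a carboxylic acid or a longer chain in place of these hydroxylated groups would keep clearance in the same range remains unknown. Also open, on these data alone, is whether the same change would read alike on the core of compound 3, which gives 35 mL/min/kg, since a single step on the core of compound 1 says nothing about a second core.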